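A Saturated Ring Replaces 4-Fluorophenyl

A few compounds are considered here, and "the series" means these few. Any claim that something is new, unique, unknown or untested is made for them only; others in the source may bear on it.

Within the data shown here, compound 3 `COc1cc2nccc(Oc3ccc(Nc4nn(C)cc4C(=O)Nc4ccc(F)cc4)cc3)c2cc1C(N)=O` gives 3060 nM in a functional assay on BaF3 cells (Mus musculus) for antiproliferative activity, read by CCK-8 assay and cell counting, with a stated time of 76 h (a lower number here means a stronger inhibitor, a higher number a weaker inhibitor), and holds the only true number so far. Compound 1 `COc1cc2nccc(Oc3ccc(Nc4nn(C)cc4C(=O)NCc4ccccc4)cc3)c2cc1C(N)=O` gives > 10000 nM as a limit of the assay, not a number. Compound 2 `COc1cc2nccc(Oc3ccc(Nc4nn(C)cc4C(=O)Nc4ccccc4)cc3)c2cc1C(N)=O` gives > 10000 nM as a limit too. Compound 4 `COc1cc2nccc(Oc3ccc(Nc4nn(C)cc4C(=O)NCC4CCCCC4)cc3)c2cc1C(N)=O` differs from compound 3 by cyclohexylmethyl in place of 4-fluorophenyl on an amide-type nitrogen as cyclohexylmethyl takes the place of 4-fluorophenyl on an amide-type nitrogen. Among the measured compounds shown here, two measured steps bear on this: one is an at least 3.2-fold lower number from compound 1 to compound 3 (0.51 log units; beyond the scatter) and the other is an at least 3.2-fold lower number from compound 2 to compound 3 (0.51 log units; beyond the scatter) so both favour the 4-fluorophenyl group. Losing that group should therefore weaken compound 4, and the expected change is a 2.9-fold higher number from compound 3 to compound 4 (0.47 log units; beyond the scatter) in this estimate. Compound 4 is estimated at 9000 nM with an expected range from 3500 nM to 23000 nM in this assay and may well reach the limit.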

Compound 4, half-maximal inhibitory concentration: > 10000 nM
Compound 4 ended at the assay's limit; the forecaster's own chance of this, stated with the estimate: 50%; middle value at least 1.1-fold (0.04 log units) from the limit.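

Cyclohexylmethyl in place of 4-fluorophenyl on the amide-type nitrogen gives an at least 3.2-fold higher number from compound 3 to compound 4 (0.51 log units; beyond the scatter), so this saturated group does not keep the activity of compound 3. Compound 1, compound 2 and compound 3 all carry an aromatic ring here, and compound 4 extends the comparison to a non-aromatic ring. Of these four groups, only 4-fluorophenyl gives a true number.

The steps from compound 1 and compound 2 to compound 4 cannot be read, because each joins two limits: the limit of > 10000 nM in this assay, at which 3 of the 4 values shown sit. Going by these compounds, whether 4-chlorophenyl, 4-methoxyphenyl or a ring carrying an amine would give a lower number than compound 3 stays open.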